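Vinylcarbonyl on the amino nitrogen of compound 2

The source may report more compounds than this note shows. Statements on the series, on what has been measured and on what is new or still open speak of the compounds shown alone.

For the measured compounds named here, in a functional assay on NCI-H460 cells (Homo sapiens) for inhibition, read by MTT assay, with a stated time of 72 h (a higher number here means a weaker inhibitor, a lower number a stronger inhibitor), compound 2 (`Nc1cccc(C(=O)/C=C2/C(=O)Nc3ccccc32)c1`) gives 20400 nM and stands highest of the two numbers so far. Compound 1 (`CC(C)C(=O)Nc1cccc(C(=O)/C=C2/C(=O)Nc3ccccc32)c1`) gives 9700 nM in the same read-out. Compound 3 (`C=CC(=O)Nc1cccc(C(=O)/C=C2/C(=O)Nc3ccccc32)c1`) carries vinylcarbonyl in place of hydrogen on a nitrogen on an aromatic ring. Going by the values given here, the one measured step bearing on this, a 2.1-fold higher number from compound 1 to compound 2 (0.32 log units; beyond the scatter) on replacing isopropylcarbonyl with hydrogen, is modest but beyond the scatter. Read in reverse, it suggests a similarly modest fall in the number, though no vinylcarbonyl compound has been measured. An estimated step (a 2.4-fold lower number from compound 2 to compound 3 (0.38 log units; beyond the scatter)) of about that size is expected. For compound 3 the estimate is 8500 nM within 2500 nM to 20000 nM as the expected range.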

Compound 3, half-maximal inhibitory concentration: 3200 nM
Compound 3: the middle estimate sits 2.7-fold (0.42 log units) above what was measured, within the range that was stated.
By their numbers in this assay, from the lowest: compound 3; then compound 1; then compound 2.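

On the amino nitrogen, vinylcarbonyl in place of hydrogen gives a 6.4-fold lower number from compound 2 to compound 3 (0.80 log units; beyond the scatter) in this assay and sets compound 3 lowest of the series. The acyl group itself matters, not acylation alone: vinyl in place of isopropyl on the carbonyl carbon gives a 3.0-fold lower number from compound 1 to compound 3 (0.48 log units; beyond the scatter) as a further fall beyond the scatter. No available evidence bears on what lies behind this difference.

Open, going by these compounds, is whether ethyl on the carbonyl carbon, the saturated counterpart of vinyl, reads like isopropyl or like vinyl. Also open, on these data alone, is whether a methyl group on the vinyl keeps the lower number.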